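Ester to anilide at the carbonyl of the shared core

This account rests on a few compounds, and the source may have more. Where it says the series, first, only, none or still open, it means among the compounds named here.

Measured compounds in an assay on cells for agonist activity at vitamin D3 receptor (Homo sapiens), with a stated time of 96 h; on this read-out lower numbers stand for an effect already at smaller amounts and higher numbers for an effect only at larger amounts of compound:
compound 1 `CCn1c(C(=O)NCCN(C)C)ccc1C(CC)(CC)c1ccc(OCCC(O)(CC)CC)c(C)c1` gives 82 nM
compound 2 `CCn1c(C(=O)NCC#N)ccc1C(CC)(CC)c1ccc(OCCC(O)(CC)CC)c(C)c1` gives 1080 nM
compound 3 `C#CC(C)OC(=O)c1ccc(C(CC)(CC)c2ccc(OCCC(O)(CC)CC)c(C)c2)n1CC` gives 2650 nM

Compound 3 stands highest of the three numbers. Its nearest neighbour is compound 2, from which the step of a 2.5-fold higher number from compound 2 to compound 3 (0.39 log units; beyond the scatter) is seen; its furthest is compound 1, from which the step of a 32-fold higher number from compound 1 to compound 3 (1.51 log units; beyond the scatter) is seen. Both measured amides sit below the ester, though they differ from each other by a 13-fold higher number from compound 1 to compound 2 (1.12 log units; beyond the scatter), so the substituent on the amide nitrogen carries much of the spread.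

Compound 4 `CCOc1ccc(NC(=O)c2ccc(C(CC)(CC)c3ccc(OCCC(O)(CC)CC)c(C)c3)n2CC)cc1` carries the change ((4-ethoxyphenyl)amino in place of (1-methylprop-2-yn-1-yl)oxy on a carbonyl carbon). Compound 4 is an amide, like compounds 1 and 2, so the two steps from the amides to the ester bear on it directly, and both were beyond the scatter in the direction of higher numbers for the ester. The reverse direction, ester to amide, is therefore expected to give a lower number. Going by the values given here, no measured compound carries an aromatic ring on the amide nitrogen, so the size is uncertain; the expectation is placed between the two measured amides rather than at either.

Compound 4 is expected to give 600 nM in this assay, within 120 nM to 3000 nM, an expected step of a 4.4-fold lower number from compound 3 to compound 4 (0.65 log units; beyond the scatter).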

Compound 4, half-maximal effective concentration: 1630 nM
Compound 4: middle estimate off by 2.7-fold (0.43 log units), on the low side; low and high end bracket the measured number.
By their numbers in this assay, from the lowest: compound 1; then compounds 2, 4 and 3 (each within the scatter of the next, the first and the last beyond it).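

In this assay, exchanging the (1-methylprop-2-yn-1-yl)oxy group on the carbonyl carbon for (4-ethoxyphenyl)amino leaves the two compounds within the scatter of each other (a 1.6-fold lower number from compound 3 to compound 4 (0.21 log units; within the scatter)), so an amide at this carbonyl does not by itself separate a compound from the ester, although compound 2, also an amide, does stand apart from compound 3 beyond the scatter. On the amide nitrogen, 4-ethoxyphenyl and cyanomethyl cannot be told apart (a 1.5-fold higher number from compound 2 to compound 4 (0.18 log units; within the scatter)), even though only the first brings a six-membered aromatic ring, whereas 4-ethoxyphenyl and 2-(dimethylamino)ethyl lie far apart (a 20-fold higher number from compound 1 to compound 4 (1.30 log units; beyond the scatter)). Among the three amides, compound 1 is therefore the only one set apart from the other two, and the earlier reading of the amides as a group lower than the ester now holds clearly for compound 1 and compound 2 only.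

As far as these compounds go, it remains open whether the number of compound 1 goes with the dimethylamino group or with the chain carrying it, which a 3-(dimethylamino)propyl or a 2-methoxyethyl group on the amide nitrogen would help to separate. No measurement on hand accounts for any of these steps.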